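Bromine for Chlorine on a Ring-Expanded Core

The source may report more compounds than this note shows. Statements on the series, on what has been measured and on what is new or still open speak of the compounds shown alone.

Measured in a functional assay on P388 cells (Mus musculus) for inhibition; on this read-out lower numbers stand for stronger inhibition and higher numbers for weaker inhibition:
compound 1 `O=C1/C(=C/c2cccc(Cl)c2)Cc2ccccc21`: 26300 nM
compound 2 `O=C1/C(=C/c2cccc(Br)c2)Cc2ccccc21`: 21000 nM
compound 3 `O=C1/C(=C/c2ccc(Cl)cc2)CCCc2ccccc21`: 9500 nM

Compound 1 and compound 2 share one core and differ by bromo in place of chloro on an aromatic carbon; that change gave a 1.3-fold lower number from compound 1 to compound 2 (0.10 log units; within the scatter). Compound 3 is built on a different core; how the two cores differ is not broken down here. In this assay compound 3 stands lowest of the three numbers, beyond the scatter from both compound 1 and compound 2.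

Compound 4 `O=C1/C(=C/c2ccc(Br)cc2)CCCc2ccccc21` is not yet measured. It differs from compound 3 by bromo in place of chloro on an aromatic carbon. Going by the values given here, this is the same kind of change as the one from compound 1 to compound 2, but not the same: there the place was meta to a large group, here it is para to a large group. Resting on compound 3 and on the small step seen in a 1.3-fold lower number from compound 1 to compound 2 (0.10 log units; within the scatter), compound 4 is expected to give 8000 nM, between 3000 nM and 22000 nM, the expected step from compound 3 being a 1.2-fold lower number from compound 3 to compound 4 (0.07 log units; within the scatter).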

Compound 4, half-maximal inhibitory concentration: 18600 nM
The estimate for compound 4 lay 2.3-fold (0.37 log units) below the measured number, and the stated range covers the measured number.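

In this assay, bromo in place of chloro on an aromatic carbon, here para to a large group, gave a 2.0-fold higher number from compound 3 to compound 4 (0.29 log units; within the scatter). Set beside the earlier step on the other core, the two results do not separate: the same change on two cores in this assay, a 1.3-fold lower number (0.10 log units; within the scatter) from compound 1 to compound 2 and a 2.0-fold higher number (0.29 log units; within the scatter) from compound 3 to compound 4, 2.5-fold (0.39 log units) apart, within the scatter of two such steps. The change therefore carried from one core to the other without a step or a gap that stands clear of the scatter, but this does not show that the two cores respond alike, since each core supplies a single pair and the place of the halogen differs between the pairs, so the effect of core and the effect of place cannot be told apart.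

Going by these compounds, whether a fluoro group, a methoxy group or an amine at the same place would give a different number remains open. Also open, on these data alone, is how chloro and bromo would compare on each core if they were held at the same place on both.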